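Sulfanyl in place of hydrogen on a nucleoside

The compounds below may be only part of what the source reports. "The series", "measured", "known", "first", "only" and "open" are said of these compounds alone.

Compound 1, `CC1OC(n2cnc3c(N)nccc32)CC1O`: 3%
Compound 2, `OC[C@H]1O[C@@H](n2cnc3cnccc32)[C@H](O)[C@@H]1O`: 13%; 1% (2 entries)
Compound 3, `OC[C@H]1O[C@@H](n2cnc3cnccc32)C[C@@H]1O`: 6%

All three measured compounds were tested in a functional assay (Homo sapiens) for inhibition of Nucleic Acid, tested at 100 uM; a higher number here means more inhibition at the concentration tested (going by the name of the read-out), a lower number less inhibition. Compound 3 gives 6% there, the highest of the two single numbers, but its nearest neighbour is compound 1 with 3%, a gap that lies within the scatter, so no order between compound 3 and compound 1 can be read from these values. Compound 2 carries two entries in this assay, 13%; 1% (2 entries), and their spread alone is as wide as anything seen here (the several entries of compound 2 in this assay, 13%; 1% (2 entries)). Taken together, the three compounds sit at the low end of the read-out and no step between them stands out.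

Compound 4, `OC[C@H]1O[C@@H](n2cnc3c(S)nccc32)C[C@@H]1O`, has not yet been measured. It differs from compound 3 by sulfanyl in place of hydrogen on an aromatic carbon. Going by the values given here, with no step between measured compounds beyond the scatter to build on, the step of a number 4 percentage points higher from compound 3 to compound 4 (within the scatter) is expected to stay within the scatter, in no fixed direction. The value of compound 4 in this assay is therefore estimated at 10%, between 0% and 30%.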

Compound 4, a percentage reported as inhibition, at one concentration (the size of the read-out at that concentration, not a potency): 10%
Estimate against measurement, compound 4: no gap at the digits printed; the range from low to high includes it.
By their numbers in this assay, from the lowest: compounds 1, 3 and 4 (each within the scatter of the next).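

In this assay, sulfanyl in place of hydrogen on an aromatic carbon, next to the ring nitrogen of the six-membered aromatic ring, gives a number 4 percentage points higher from compound 3 to compound 4 (within the scatter). This is the first pair among the compounds shown that differ in one place, so it offers the first direct look at this position, and what it shows is that this single change brings no readable shift in inhibition at the concentration tested. A step of this size cannot be separated from the spread of repeated entries, which is at least as wide for a single compound in the same assay: the several entries of compound 2 in this assay, 13%; 1% (2 entries)

What the compounds shown leave open is whether a different group at this same carbon, such as a methylsulfanyl group, a chlorine atom or a carboxylic acid, would move the read-out beyond the scatter. From the compounds shown here alone, it also remains open whether sulfanyl at this place would give a larger step on the core of compound 2, which carries one more hydroxyl group on its sugar ring than compound 3.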